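The compounds below may be only part of what the source reports. "The series", "measured", "known", "first", "only" and "open" are said of these compounds alone.

Working notes on the series

Three compounds of the shared core have numbers in a functional assay on K562 cells (Homo sapiens) for antiproliferative activity, read by MTT assay, with a stated time of 6 days; a higher number here means a weaker inhibitor, a lower number a stronger inhibitor. Compound 1 `COc1ccc(/C=C/C(=O)OC[C@@H](OCc2ccccc2)[C@H]2OC(=O)C=C[C@H]2OCc2ccccc2)cc1` gives 430 nM, the lowest of the three, and stands apart from both others by more than the usual scatter. Compound 2 `COc1cccc(C(=O)OC[C@@H](OC(=O)c2cccc(OC)c2)[C@H]2OC(=O)C=C[C@H]2OC(=O)c2cccc(OC)c2)c1` gives 4650 nM, and compound 3 `CC(=O)OC[C@@H](OC(C)=O)[C@H]1OC(=O)C=C[C@H]1OC(C)=O` gives 7540 nM, the highest of the three. No pair among these three differs in only one place, so no single step can be read directly; what the numbers show is that compound 1, carrying the 2-(4-methoxyphenyl)ethenyl carbonyl ester together with two benzyl ethers, sits well below compound 3, which carries acetyl at all three positions.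

Compound 4 `CC(=O)OC[C@@H](OCc1ccccc1)[C@H]1OC(=O)C=C[C@H]1OCc1ccccc1` differs from compound 1 in a single place: methyl in place of 2-(4-methoxyphenyl)ethenyl on a carbonyl carbon. The two benzyl ethers of compound 1 are kept. The change runs toward the acetyl pattern of compound 3, so an increase in number is expected, but because compound 4 retains the benzyl ethers that compound 3 lacks while compound 3 gives 7540 nM, the increase is expected to stop short of that number. Compound 4 is therefore expected at 2000 nM, with a plausible range of 600 nM to 6500 nM. The step from compound 1 to compound 4 is estimated as a 4.7-fold higher number from compound 1 to compound 4 (0.67 log units; beyond the scatter) in this assay , a loss beyond the scatter.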

Compound 4, half-maximal inhibitory concentration: 880 nM
Estimate against measurement, compound 4: 2.3-fold (0.36 log units) above, and the stated range covers the measured number.
By their numbers in this assay, from the lowest: compound 1; then compound 4; then compounds 2 and 3 (each within the scatter of the next).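

Methyl in place of 2-(4-methoxyphenyl)ethenyl on a carbonyl carbon, with the two benzyl ethers kept, gives a 2.0-fold higher number from compound 1 to compound 4 (0.31 log units; beyond the scatter) in this assay, the first change in the series that can be read in one place. The step is beyond the scatter but modest: with the aromatic ring and the double bond of the larger group both gone, compound 4 still gives 880 nM, so at this position the 2-(4-methoxyphenyl)ethenyl group is not needed for a number of this order. Nothing measured here accounts for the size of the step.

The compounds shown leave open whether the aromatic ring, the double bond or the methoxy group of 2-(4-methoxyphenyl)ethenyl carries the difference, and how a plain phenyl, a longer alkyl chain or a chain ending in an amine would read on the same carbonyl carbon. The contribution of the two benzyl ethers also stays open, as no pair shown changes them alone.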